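This account rests on a few compounds, and the source may have more. Where it says the series, first, only, none or still open, it means among the compounds named here.

Measured compounds:
- compound 1, `COc1cccc(NC(=S)NCCNS(=O)(=O)c2ccc(-c3ccccc3Oc3ccc([N+](=O)[O-])cc3)s2)c1`; in a functional assay on RS4-11 cells (Homo sapiens) for inhibition, read by CCK-8 assay, with a stated time of 48 h (on this read-out higher numbers stand for weaker inhibition and lower numbers for stronger inhibition), compound 1 gives > 50000 nM, which is a limit of the assay rather than a number.
- compound 2, `COc1ccc(NC(=O)NCCNS(=O)(=O)c2ccc(-c3ccccc3Oc3ccc([N+](=O)[O-])cc3)s2)cc1`; in this assay compound 2 gives > 50000 nM, again only a limit.
- compound 3, `O=[N+]([O-])c1ccc(Oc2ccccc2-c2ccc(S(=O)(=O)NCCNC(=S)Nc3cccc(Cl)c3)s2)cc1`; in this assay compound 3 gives > 50000 nM, also a limit.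

Compound 2 therefore stands nowhere in particular among these three: all of them sit at the same limit, as the summary the limit of > 50000 nM in this assay, at which 3 of the 3 values shown sit, states, so no order among them can be read. The measured steps a step that the two limits leave unreadable from compound 1 to compound 2, a step that the two limits leave unreadable from compound 1 to compound 3 and a step that the two limits leave unreadable from compound 2 to compound 3 all change the group on the amine nitrogen at one end of the shared core, and each is unreadable for the same reason.

Compound 4, `COc1ccc(NC(=O)NCCNS(=O)(=O)c2ccc(-c3ccccc3OCc3cccc(O)c3)s2)cc1`, changes the other end of the core instead: 3-hydroxybenzyl in place of 4-nitrophenyl on an oxygen on an aromatic ring. Going by the values given here, none of the measured steps touches this position, so nothing here says in which direction, or how far, the number might move. The plain expectation is that compound 4 in this assay stays near the limit, with a step of a number no higher from compound 2 to compound 4 (the limit leaves the size open) expected. Compound 4 is thus estimated at 50000 nM, expected to lie between 15000 nM and 200000 nM.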

Compound 4, half-maximal inhibitory concentration: 9400 nM
Compound 4: the middle estimate sits 5.3-fold (0.73 log units) above what was measured; the whole stated range lies above it.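

In this assay, swapping 4-nitrophenyl for 3-hydroxybenzyl on the oxygen on an aromatic ring gives an at least 5.3-fold lower number from compound 2 to compound 4 (0.72 log units; beyond the scatter). Going by these compounds alone, compound 4 is the only one of the four compounds with a value that reads as a number, so this end of the shared core can move the read-out, something the changes on the amine nitrogen could not show, as those steps cannot be read. The true size of the step stays open because compound 2 gives only a limit: the limit of > 50000 nM in this assay, at which 3 of the 4 values shown sit.

The change replaces a whole group, so the compounds shown do not separate the part played by the hydroxy group from that of the benzyl carbon or the loss of the nitro group. Also open, on these data alone, is what a plain benzyl, or a benzyl carrying an amine or a carboxylic acid, would give, and whether the groups of compound 1 and compound 3 on the amine nitrogen would read differently alongside 3-hydroxybenzyl.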